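This account rests on a few compounds, and the source may have more. Where it says the series, first, only, none or still open, it means among the compounds named here.

Compound 1, `O=C(/C=C/c1cccnc1)NCCCCCc1ccc(S(=O)(=O)Nc2ccccc2)cc1`, gives 28.4 nM in an assay on isolated protein for inhibition of Nicotinamide phosphoribosyltransferase (Homo sapiens), read by WST assay, with stated times of 60 min, 5 min and 30 min, in the presence of a further agent that is not named here; on this read-out higher numbers stand for weaker inhibition and lower numbers for stronger inhibition.
Compound 2, `Cc1cccc(NS(=O)(=O)c2cccc(CCCCCCNC(=O)/C=C/c3cccnc3)c2)c1`, gives 12.3 nM in this assay.

Of these two, compound 2 has the lower number, and its gap to compound 1 lies beyond the usual scatter of repeated measurements, so compound 2 is the stronger inhibitor of the pair shown so far. Compound 3, `O=C(/C=C/c1cccnc1)NCCCCCCc1cccc(S(=O)(=O)Nc2ccc(F)c(Cl)c2)c1`, has not yet been measured. It differs from compound 2 in a single place: 3-chloro-4-fluorophenyl in place of 3-methylphenyl on a sulfonamide nitrogen. For the measured compounds named here, no pair of measured compounds shows this particular change, so there is nothing in the data to say how large its effect will be or in which direction it will go. Both measured compounds carry a substituted phenyl on the sulfonamide nitrogen and land in the same region of the read-out, which gives no reason to expect a large shift. The step of a 1.0-fold lower number from compound 2 to compound 3 (0.01 log units; within the scatter) is therefore expected to stay within the scatter. The estimate for compound 3 in this assay is 12 nM, with a range from 5 nM to 30 nM.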

Compound 3, half-maximal inhibitory concentration: 9.7 nM
Estimate against measurement, compound 3: 1.2-fold (0.09 log units) above; the range from low to high includes it.
By their numbers in this assay, from the lowest: compounds 3 and 2 (each within the scatter of the next); then compound 1.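

On the sulfonamide nitrogen, 3-chloro-4-fluorophenyl can stand in place of 3-methylphenyl with no change that can be distinguished in this assay: the measured move is a 1.3-fold lower number from compound 2 to compound 3 (0.10 log units; within the scatter), so compounds 2 and 3 cannot be ranked against each other. For the compounds shown here, this is the first comparison in which only this group varies while the rest of the molecule stays fixed, and it shows that a ring bearing chlorine and fluorine and a ring bearing methyl give numbers of the same size here. No measurement available here explains why this swap has so little visible effect.

Going by these compounds, it remains open whether the sulfonamide nitrogen would keep such numbers with something other than a phenyl ring on it, such as a pyridine ring, a cyclohexyl ring or a short alkyl chain carrying an amine or a carboxylic acid. Going by these compounds alone, the swap has also been seen only on the core of compound 2, so the same change on the core of compound 1 could give a different result.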